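One More Chain Carbon at Compound 4

A few compounds are considered here, and "the series" means these few. Any claim that something is new, unique, unknown or untested is made for them only; others in the source may bear on it.

In a functional assay on KB cells (Homo sapiens) for cytotoxicity, read by resazurin assay, with a stated time of 3 days (a higher number here means a weaker inhibitor, a lower number a stronger inhibitor), compound 1 `CCCCCCC(=O)NCC(C)(C)CC1=C(O)C(=O)c2ccccc2C1=O` gives 28200 nM and compound 2 `CCCCCCCC(=O)NCC(C)(C)CC1=C(O)C(=O)c2ccccc2C1=O` gives 24600 nM while compound 3 `CCCCCCCCC(=O)NCC(C)(C)CC1=C(O)C(=O)c2ccccc2C1=O` gives 19700 nM and so stands within the scatter of both. Compound 4 `CCCCCCCCCC(=O)NCC(C)(C)CC1=C(O)C(=O)c2ccccc2C1=O` differs from compound 3 by methyl in place of hydrogen on a saturated chain carbon, eight bonds along the chain from a carbonyl carbon that is, methyl in place of hydrogen on a saturated chain carbon, eight bonds along the chain from a carbonyl carbon. The closest measured precedents are the same change nearer the carbonyl carbon (a 1.1-fold lower number from compound 1 to compound 2 (0.06 log units; within the scatter)) and (a 1.2-fold lower number from compound 2 to compound 3 (0.10 log units; within the scatter)) and the two-carbon step (a 1.4-fold lower number from compound 1 to compound 3 (0.16 log units; within the scatter)). All three stay within the scatter. No step beyond the scatter is therefore expected, and the estimated step is small (a 1.2-fold lower number from compound 3 to compound 4 (0.06 log units; within the scatter)). The estimated value for compound 4 is 17000 nM with an expected range (from 9000 nM to 30000 nM).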

Compound 4, half-maximal inhibitory concentration: 18500 nM
Estimate against measurement, compound 4: 1.1-fold (0.04 log units) below, and the stated range covers the measured number.
By their numbers in this assay, from the lowest: compounds 4, 3, 2 and 1 (each within the scatter of the next).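

In this assay, methyl in place of hydrogen on a saturated chain carbon, eight bonds along the chain from a carbonyl carbon, still gives a step within the scatter (a 1.1-fold lower number from compound 3 to compound 4 (0.03 log units; within the scatter)), so this position reads like the nearer one: the same change on two cores in this assay, a 1.1-fold lower number (0.06 log units; within the scatter) from compound 1 to compound 2 and a 1.1-fold lower number (0.03 log units; within the scatter) from compound 3 to compound 4, 1.1-fold (0.03 log units) apart, within the scatter of two such steps.

Larger additions also stay within the scatter, with a 1.3-fold lower number from compound 2 to compound 4 (0.12 log units; within the scatter) and a 1.5-fold lower number from compound 1 to compound 4 (0.18 log units; within the scatter), and the ethyl step repeats its earlier counterpart: the same change on two cores in this assay, a 1.4-fold lower number (0.16 log units; within the scatter) from compound 1 to compound 3 and a 1.3-fold lower number (0.12 log units; within the scatter) from compound 2 to compound 4, 1.1-fold (0.03 log units) apart, within the scatter of two such steps.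

As far as these compounds go, whether a longer chain would produce a step beyond the scatter stays open. So does the effect of an amine or a carboxylic acid on this chain.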